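Aryl exchange from compound 2 to compound 3

The source may hold more compounds than are shown below. What is called first, only, known or untested is meant among the compounds shown, and "the series" means these compounds.

- compound 1 `CCC1=C(O)c2c(oc(-c3cccc(OC)c3)cc2=O)C(CC)(CC)C1=O` gives 1.22 uM
- compound 2 `CCC1=C(O)c2c(oc(-c3ccc(C)c(Cl)c3)cc2=O)C(CC)(CC)C1=O` gives 2.15 uM

Both values come from a functional assay on KBVIN cells (Homo sapiens) for antiproliferative activity, read by sulforhodamine B assay, with a stated time of 3 days; a lower number here means that less compound is needed, a higher number that more compound is needed for the effect. Compound 2 has only compound 1 for comparison, and the two lie within the scatter of each other: a 1.8-fold higher number from compound 1 to compound 2 (0.25 log units; within the scatter).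

The next member is compound 3 `CCC1=C(O)c2c(oc(-c3cc(C)c(C)cc3C)cc2=O)C(CC)(CC)C1=O`. Its difference from compound 2 is 2,4,5-trimethylphenyl in place of 3-chloro-4-methylphenyl on an aromatic carbon. The exchange sits on an aromatic carbon next to the ring oxygen, and 2,4,5-trimethylphenyl replaces 3-chloro-4-methylphenyl there.

For the measured compounds named here, one measured step bears on this exchange. It changed the aryl group at the same place, 3-chloro-4-methylphenyl in place of 3-methoxyphenyl, and stayed within the scatter: a 1.8-fold higher number from compound 1 to compound 2 (0.25 log units; within the scatter). Going by the values given here, no measured compound carries 2,4,5-trimethylphenyl, so this single step is weak guidance, and the range is kept wide on both sides. No change beyond the scatter is expected in this assay. The estimated step is a 1.1-fold lower number from compound 2 to compound 3 (0.03 log units; within the scatter). Compound 3 is expected at 2 uM, with an estimated range of 0.9 uM to 5 uM.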

Compound 3, concentration for half-maximal effect: 4.37 uM
The estimate for compound 3 lay 2.2-fold (0.34 log units) below the measured number; the measured number falls inside the stated range.
By their numbers in this assay, from the lowest: compounds 1 and 2 (each within the scatter of the next); then compound 3.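

In this assay, exchange of the aryl group on the aromatic carbon next to the ring oxygen now gives a change beyond the scatter, which the earlier exchange at this place did not: 2,4,5-trimethylphenyl raises the number both against 3-chloro-4-methylphenyl (a 2.0-fold higher number from compound 2 to compound 3 (0.31 log units; beyond the scatter)) and against 3-methoxyphenyl (a 3.6-fold higher number from compound 1 to compound 3 (0.55 log units; beyond the scatter)), and both steps are modest. Compound 3 therefore has the highest number of the three, and this place is shown to respond to the choice of aryl group, even though the groups entering and leaving in the step from compound 2 have the same ring and the same counts of zero hydrogen-bond donors and acceptors. Nothing available explains the rise in the number.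

The step from compound 2 swaps the whole aryl group, so the loss of chlorine and the gain of methyl groups cannot be separated, and three aryl groups give no trend in substitution. Also open, going by these compounds, is how this place responds to unsubstituted phenyl, to an aryl group bearing an amine or a carboxylic acid, or to a longer alkyl chain in place of the aryl group.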